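The source may hold more compounds than are shown below. What is called first, only, known or untested is meant among the compounds shown, and "the series" means these compounds.

Measured compounds:
Compound 1, `C/C(=N/NC(=S)Nc1ccc(Cl)cc1)c1ccccn1`, which in a functional assay on U-87MG ATCC cells (Homo sapiens) for cytotoxicity, read by MTT assay, with a stated time of 48 h (on this read-out higher numbers stand for weaker inhibition and lower numbers for stronger inhibition), gives 1.7 nM.
Compound 2, `CC(=NNC(=S)Nc1ccc(Cl)cc1)c1ccccn1`, for which compound 2 gives 1.7 nM.
Compound 3, `C/C(=N\NC(=S)Nc1ccc(Cl)cc1)c1ccccn1`, for which compound 3 gives 1.7 nM.

The three measured compounds have the same atoms and bonds and differ only in how the double bond is drawn, as shown by the fact that one of compounds 1 and 2 is drawn with a defined configuration and the other without, at the place where they differ, the fact that compounds 1 and 3 differ only in the configuration as drawn and (the fact that one of compounds 2 and 3 is drawn with a defined configuration and the other without, at the place where they differ). Going by the values given here, the steps of no change at the digits printed from compound 1 to compound 2 (within the scatter), no change at the digits printed from compound 1 to compound 3 (within the scatter) and no change at the digits printed from compound 2 to compound 3 (within the scatter) all stay within the scatter, so compound 1 stands level with compounds 2 and 3 in this assay, and the single value they share is the only anchor.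

Compound 4, `C/C(=N/NC(=S)Nc1ccc(I)cc1)c1ccccn1`, arises from compound 1 by iodo in place of chloro on an aromatic carbon. Among the compounds with values here, none of the measured steps touches the halogen; each keeps the chloro and changes only the drawn configuration, so they say nothing about the size of this step, and the expectation rests on compound 1 alone at 1.7 nM. A step of about no change at the digits printed from compound 1 to compound 4 (within the scatter) is expected, that is, no change beyond the scatter. Compound 4 is therefore estimated at 1.7 nM in this assay, with a range from 0.5 nM to 6 nM.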

Compound 4, half-maximal inhibitory concentration: 59 nM
Compound 4: the middle estimate sits 35-fold (1.54 log units) below what was measured, and the stated range ends below it.
By their numbers in this assay, from the lowest: compounds 1, 2 and 3 (each within the scatter of the next); then compound 4.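

In this assay, going by these compounds alone, the halogen on this aromatic carbon proves to matter, which the earlier compounds could not show, as all of them keep the chloro and differ only in how the double bond is drawn. Iodo in place of chloro gives a 35-fold higher number from compound 1 to compound 4 (1.54 log units; beyond the scatter), so the activity depends on which halogen sits at this place, although the swap leaves the heavy-atom count and the hydrogen-bond donor and acceptor counts unchanged. Nothing known here bears on why this step is so large.

Going by these compounds, it remains open whether the loss is specific to iodo or extends to other groups on this carbon, such as fluoro, bromo, methoxy or an amine. On these data alone, it also remains open whether the iodo compound would stay unchanged with its double bond drawn the other way, as the chloro compounds do.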